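From an Aryl to an Arylamino Group on One Core

The compounds below may be only part of what the source reports. "The series", "measured", "known", "first", "only" and "open" are said of these compounds alone.

Three compounds share one core and differ only in the aromatic group attached to it: compound 1 `COc1cc(C(=O)c2sc3ccccc3c2-c2ccccc2)cc(OC)c1OC`, compound 2 `COc1cc(C(=O)c2sc3ccccc3c2-c2ccc(SC)cc2)cc(OC)c1OC` and compound 3 `COc1ccc(-c2c(C(=O)c3cc(OC)c(OC)c(OC)c3)sc3ccccc23)c(OC)c1`. In a functional assay on HL-60 cells (Homo sapiens) for antiproliferative activity, read by MTT assay, with a stated time of 72 h (on this read-out higher numbers stand for weaker inhibition and lower numbers for stronger inhibition), compound 1 gives 1700 nM, compound 2 gives 1300 nM and compound 3 gives 4600 nM. Compound 3 therefore has the highest number of the three, and its steps to both others lie beyond the scatter.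

The next structure is compound 4 `COc1cc(C(=O)c2sc3ccccc3c2Nc2ccc(C)cc2)cc(OC)c1OC`, and the change is (4-methylphenyl)amino in place of 2,4-dimethoxyphenyl on an aromatic carbon. Here (4-methylphenyl)amino stands in place of 2,4-dimethoxyphenyl on an aromatic carbon of a five-membered aromatic ring with 1 sulfur.

Among the compounds with values here, three measured steps bear on this place. Methylsulfanyl in place of hydrogen gave a 1.3-fold lower number from compound 1 to compound 2 (0.12 log units; within the scatter), while introducing 2,4-dimethoxyphenyl gave a 2.7-fold higher number from compound 1 to compound 3 (0.43 log units; beyond the scatter) and a 3.5-fold higher number from compound 2 to compound 3 (0.55 log units; beyond the scatter). Both steps to compound 3 are modest, and neither of the other two compounds carries 2,4-dimethoxyphenyl. Within the data shown here, none of the measured compounds has an amino group at this carbon, so any forecast remains uncertain.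

A modest fall back toward the other two compounds is expected, and the estimated step in this assay is a 3.5-fold lower number from compound 3 to compound 4 (0.55 log units; beyond the scatter). For compound 4 the estimated value is 1300 nM, with an expected range from 250 nM to 5000 nM.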

Compound 4, half-maximal inhibitory concentration: 4600 nM
Beside the measured number, compound 4's estimate is 3.5-fold (0.55 log units) below it; low and high end bracket the measured number.
By their numbers in this assay, from the lowest: compounds 2 and 1 (each within the scatter of the next); then compounds 3 and 4 (each within the scatter of the next).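

In this assay, within the data shown here, the first group at this carbon of the five-membered ring to be attached through nitrogen brings no return toward the lower numbers: (4-methylphenyl)amino in place of 2,4-dimethoxyphenyl gives no change at the digits printed from compound 3 to compound 4 (within the scatter) on this read-out. Compound 4 therefore keeps the same distance from the other two compounds as compound 3 does, with a 3.5-fold higher number from compound 2 to compound 4 (0.55 log units; beyond the scatter) and with a 2.7-fold higher number from compound 1 to compound 4 (0.43 log units; beyond the scatter), both steps modest. Until now the higher number had been seen only with 2,4-dimethoxyphenyl, but it also appears here with a group that has a nitrogen link, a hydrogen-bond donor and no methoxy group, so among these compounds it does not depend on methoxy groups.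

The compounds shown leave open whether the higher number of compound 4 goes with the nitrogen link or with the methyl group on its ring, and a plain phenylamino group, a 4-(methylsulfanyl)phenylamino group or a phenoxy group at this carbon would separate the two. Nothing measured here gives a reason why compound 3 and compound 4 end up together.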